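The source may report more compounds than this note shows. Statements on the series, on what has been measured and on what is new or still open speak of the compounds shown alone.

Compound 1 `O=C(CCCc1ccccc1)Nc1nc2ccccc2c(=O)s1`: 229 nM in an assay on membranes from brain for displacement of a labelled ligand from adenosine receptor A1 (Rattus norvegicus), read by scintillation counting, with a stated time of 90 min; on this read-out higher numbers stand for weaker inhibition and lower numbers for stronger inhibition
Compound 2 `O=C(C/C=C/c1ccc(Cl)c(Cl)c1)Nc1nc2ccccc2c(=O)s1`: >= 1500 nM in this assay, a limit of the assay
Compound 3 `O=C(CCc1ccccc1F)Nc1nc2ccccc2c(=O)s1`: > 10000 nM in this assay, a limit of the assay

Compound 3 stands at the weak end of what is shown: its number is a limit (the limit of > 10000 nM in this assay, at which 1 of the 3 values shown sits), and among the three values only compound 1 has a measured number. Compound 4 `O=C(CCc1ccc(Cl)c(Cl)c1)Nc1nc2ccccc2c(=O)s1` differs from compound 3 by 3,4-dichlorophenyl in place of 2-fluorophenyl on a saturated chain carbon, two bonds along the chain from a carbonyl carbon. Among the compounds with values here, one measured step bears on this place on the chain, an at least 43-fold higher number from compound 1 to compound 3 (1.64 log units; beyond the scatter), which carried the series from a measured number to the limit. Compound 2, carrying the same 3,4-dichlorophenyl group on an unsaturated chain, also rests at a limit (the limit of >= 1500 nM in this assay, at which 1 of the 3 values shown sits). With both neighbours at limits, compound 4 is expected to remain weak, and the step of an at least 2.5-fold lower number from compound 3 to compound 4 (0.39 log units; beyond the scatter) is estimated to lie within the scatter or somewhat toward a stronger number, which a limit cannot resolve. For compound 4 the estimate in this assay is therefore 4000 nM, with a range from 600 nM to 25000 nM.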

Compound 4, inhibition constant: > 1500 nM
Compound 4: no number, only a limit; the forecaster's own chance of this, stated with the estimate: 45%; the middle value lies beyond the limit too.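

On the saturated chain, the 3,4-dichlorophenyl group also leaves this assay without a measured number, and compound 4 rests at a limit of its own: the limit of > 1500 nM in this assay, at which 1 of the 4 values shown sits.

A second group in place of benzyl at this place now gives a weaker result, with an at least 6.5-fold higher number from compound 1 to compound 4 (0.81 log units; beyond the scatter), so the loss is not confined to 2-fluorophenyl. The step between the two substituted phenyl groups cannot be read, as both of its ends are limits.

From the compounds shown here alone, it remains open how far beyond its limit compound 4 lies, and whether the two substituted phenyl groups differ at all in this assay. Going by these compounds, it is also open whether a longer saturated chain carrying 3,4-dichlorophenyl, or an amine at this place, would return a measured number like that of compound 1, 229 nM.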